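A few compounds are considered here, and "the series" means these few. Any claim that something is new, unique, unknown or untested is made for them only; others in the source may bear on it.

Going by the values given here, compound 1 `O=C(NO)c1ccc(N(Cc2ccc(C3CCCCC3)cc2)C(=O)[C@H]2CCN2S(=O)(=O)c2c(F)c(F)c(F)c(F)c2F)cc1O` gives 9700 nM in a functional assay on MCF7 cells (Homo sapiens) for antiproliferative activity, with a stated time of 72 h (a lower number here means that less compound is needed, a higher number that more compound is needed for the effect), the only number available for this small set. For compound 2 `O=C(NO)c1ccc(N(Cc2ccc(C3CCOCC3)cc2)C(=O)[C@H]2CCN2S(=O)(=O)c2c(F)c(F)c(F)c(F)c2F)cc1O` the entry reads "not determined" (no result reported), so compound 1 cannot be ranked against anything. Compound 3 `O=C([C@H]1CCN1S(=O)(=O)c1c(F)c(F)c(F)c(F)c1F)N(Cc1ccc(C2CCCCC2)cc1)c1cc2[nH]ncc2cc1F` keeps the rest of compound 1 and changes one group on an amide-type nitrogen, with 5-fluoro-1H-indazol-6-yl in place of 3-hydroxy-4-(hydroxycarbamoyl)phenyl (5-fluoro-1H-indazol-6-yl in place of 3-hydroxy-4-(hydroxycarbamoyl)phenyl on an amide-type nitrogen). Among the compounds with values here, no measured pair shows what such an exchange does in this assay, and the expectation rests solely on compound 1 at 9700 nM. Within the data shown here, no step clearly beyond the scatter is therefore expected, with a slight lean towards less compound being needed. The estimated change is a 1.6-fold lower number from compound 1 to compound 3 (0.21 log units; within the scatter). For compound 3 the expected value is 6000 nM, with an estimated range from 1800 nM to 20000 nM.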

Compound 3, half-maximal effective concentration: 9400 nM
The estimate for compound 3 lay 1.6-fold (0.19 log units) below the measured number, and the stated range covers the measured number.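

In this assay, going by these compounds alone, the first measured exchange in this set, 5-fluoro-1H-indazol-6-yl in place of 3-hydroxy-4-(hydroxycarbamoyl)phenyl on an amide-type nitrogen, gives a 1.0-fold lower number from compound 1 to compound 3 (0.01 log units; within the scatter). This position can therefore lose the hydroxycarbamoyl group and the hydroxyl, and gain a five-membered aromatic ring with 2 hetero atoms and a fluorine, without a step beyond the scatter, so the assay does not separate these two groups. Nothing available accounts for this outcome.

Any step involving compound 2 cannot be read, as no result is reported for it. Going by these compounds, it remains open whether a simpler group on this nitrogen, such as an unsubstituted phenyl or a phenyl bearing a carboxylic acid, would give a number clearly different from these.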